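The compounds below may be only part of what the source reports. "The series", "measured", "known", "first", "only" and "open" are said of these compounds alone.

Compound 1 `COCCOc1nc(N)nc2c1ncn2/C=C1/CC1(CO)CO`: in an ADME assay on Akata cells (Homo sapiens) for cytotoxicity, with a stated time of 7 days (on this read-out lower numbers stand for higher toxicity in this test and higher numbers for lower toxicity in this test), compound 1 reaches only the limit > 20000 nM.
Compound 2 `CC(C)Nc1nc(N)nc2c1ncn2/C=C1/CC1(CO)CO`: in this assay compound 2 reaches only the limit > 24000 nM.
Compound 3 `Nc1nc2c(ncn2/C=C2/CC2(CO)CO)c(=O)[nH]1`: in this assay compound 3 reaches only the limit > 20000 nM.

Every value here is a limit of the test rather than a number. Two of the three sit at the limit of > 20000 nM in this assay, at which 2 of the 3 values shown sit, and one at the limit of > 24000 nM in this assay, at which 1 of the 3 values shown sits, so compound 2 stands at a limit with no number of its own and nothing to rank it against its neighbours. Within the data shown here, the single measured step, a step that the two limits leave unreadable from compound 1 to compound 2, runs between two limits and its size cannot be read.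

Compound 4 `CC(C)Sc1nc(N)nc2c1ncn2/C=C1/CC1(CO)CO` differs from compound 2 in one place: isopropylsulfanyl in place of isopropylamino on an aromatic carbon. Among the measured compounds shown here, no measured step touches an isopropylsulfanyl group, and the only step known is unreadable, so there is nothing in these data that points to a move in this assay in either direction, up or down, beyond the usual scatter. The most reasonable expectation is that compound 4, like the three compounds measured, will again reach only a limit. Accordingly the expected step is an at least 1.2-fold lower number from compound 2 to compound 4 (0.07 log units; that floor lies within the scatter). Compound 4 is therefore expected to give about 20000 nM, within a range from 10000 nM to 40000 nM.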

Compound 4, half-maximal cytotoxic concentration: > 20000 nM
Compound 4: no number, only a limit; the forecaster's own chance of this, stated with the estimate: 80%; the middle value sits exactly at the limit.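

Compound 4 gives only a limit, as do compound 1 and compound 2, so neither the step from compound 2 to compound 4 nor the step from compound 1 to compound 4 can be read. The compounds shown leave open what concentration of any of them would reach the half-maximal cytotoxic level in this assay, and whether changing the group on the aromatic carbon alters it.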